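Coumarin series: from carbamoylmethoxy to hydroxymethyl

A few compounds are considered here, and "the series" means these few. Any claim that something is new, unique, unknown or untested is made for them only; others in the source may bear on it.

Compound 2 `NC(=O)COc1cc(=O)oc2cc(OCc3cccc(Br)c3)ccc12` gives 8.91 nM in an assay on isolated protein (strain Sprague-Dawley) for inhibition of Amine oxidase [flavin-containing] B (Rattus norvegicus), read by spectrophotometry, with a stated time of 5 min (a higher number here means a weaker inhibitor, a lower number a stronger inhibitor), the highest of the two single numbers; compound 1 `COc1cc(=O)oc2cc(OCc3cccc(Br)c3)ccc12` gives 5.75 nM, and the step of a 1.5-fold higher number from compound 1 to compound 2 (0.19 log units; within the scatter) is within the scatter. Compound 3 `NC(=O)COc1cc(=O)oc2cc(OCc3cccc(Cl)c3)ccc12` gives 3.1 nM; 3.31 nM (2 entries), shown by the several entries of compound 3 in this assay, 3.1 nM; 3.31 nM (2 entries). The change to compound 4 `O=c1cc(CO)c2ccc(OCc3cccc(Br)c3)cc2o1` is hydroxymethyl in place of carbamoylmethoxy on an aromatic carbon. Among the compounds with values here, the only measured step at that aromatic carbon, a 1.5-fold higher number from compound 1 to compound 2 (0.19 log units; within the scatter), stayed within the scatter when carbamoyl replaced hydrogen on the saturated chain carbon; no step here removes the ether oxygen itself. An expected step of a 1.3-fold higher number from compound 2 to compound 4 (0.13 log units; within the scatter) in this assay is therefore modest, slightly towards a higher number. Compound 4 is estimated at 12 nM, between 4 nM and 40 nM.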

Compound 4, half-maximal inhibitory concentration: 14.1 nM
Beside the measured number, compound 4's estimate is 1.2-fold (0.07 log units) below it; measured number inside the range.
By their numbers in this assay, from the lowest: compounds 1, 2 and 4 (each within the scatter of the next, the first and the last beyond it).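

At this aromatic carbon, hydroxymethyl in place of carbamoylmethoxy stays within the scatter (a 1.6-fold higher number from compound 2 to compound 4 (0.20 log units; within the scatter)) in this assay. Hydroxymethyl in place of methoxy gives the first step at this position beyond the scatter, though a modest one (a 2.5-fold higher number from compound 1 to compound 4 (0.39 log units; beyond the scatter)). No measurement shown bears on the origin of either step.

Open, on these data alone, is whether an amine, a carboxylic acid or a longer chain on this carbon would stay in the same range. Also open, as far as these compounds go, is how hydroxymethyl reads with the chlorine of compound 3 in place of the bromine.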